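Tertiary amide in a dimethoxy-tetralin acetic acid series

The source may report more compounds than this note shows. Statements on the series, on what has been measured and on what is new or still open speak of the compounds shown alone.

Measured compounds in a functional assay on the whole organism (strain Wistar) for inhibition, with Rattus norvegicus as the target, read by paw edema, with stated times of 60 min and 24 h, at a dose of 100 mg/kg by the oral route; a lower number here means less inhibition, a higher number more inhibition at the dose given (going by the name of the read-out):
compound 1 `COc1cc2c(cc1OC)C(CC(=O)O)CC2`, 26.7%;
compound 2 `CCCCNC(=O)CC1CCc2cc(OC)c(OC)cc21`, 36.7%;
compound 3 `COc1cc2c(cc1OC)C(CC(=O)NCc1ccccc1)CC2`, 43.3%.

Compound 3 holds the highest of the three numbers in this assay; its gap to compound 2 is within the scatter, while the step of a number 16.6 percentage points higher from compound 1 to compound 3 (beyond the scatter) is beyond it. Both amides sit above the free acid, as a number 10 percentage points higher from compound 1 to compound 2 (within the scatter) also shows, though that smaller step stays within the scatter. The step of a number 6.6 percentage points higher from compound 2 to compound 3 (within the scatter) is within the scatter, so exchanging a propyl for a phenyl on the amide side chain left the read-out essentially unmoved.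

Compound 4 `COc1cc2c(cc1OC)C(CC(=O)N1CCCC1)CC2` differs from compound 3 by pyrrolidin-1-yl in place of benzylamino on a carbonyl carbon. The closest measured steps are the two amide formations from compound 1 and the side-chain swap; none of them tests an amide without a donor hydrogen, so the change is largely untested here. Since the measured amides lie close together, compound 4 is expected to stay near them, with a number 7.3 percentage points lower from compound 3 to compound 4 (within the scatter) estimated to remain within the scatter. Compound 4 is expected to give about 36%, between 22% and 50%.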

Compound 4, a percentage reported as inhibition, in the whole organism at one dose (the size of the read-out at that dose, not a potency): 33.3%
Compound 4: the middle estimate sits 2.7 percentage points above what was measured, and the stated range covers the measured number.
By their numbers in this assay, from the lowest: compounds 1, 4, 2 and 3 (each within the scatter of the next, the first and the last beyond it).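

With pyrrolidin-1-yl on the carbonyl carbon, compound 4 is the only amide here without the amide hydrogen, yet in this assay it stays close to the two amides that have one, with a number 10 percentage points lower from compound 3 to compound 4 (within the scatter) and a number 3.4 percentage points lower from compound 2 to compound 4 (within the scatter). The amide hydrogen therefore shows no measurable contribution to this read-out, although the benzylamino amide remains the only one separated from the free acid by more than the scatter; the pyrrolidin-1-yl amide is not, with a number 6.6 percentage points higher from compound 1 to compound 4 (within the scatter). No measurement here bears on the reason for these readings.

Going by these compounds, it remains open whether piperidin-1-yl or dimethylamino on the same carbonyl carbon would read like pyrrolidin-1-yl. Also open, on these data alone, is whether a benzyl group on a nitrogen without the amide hydrogen would keep the separation from the free acid.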